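The source may report more compounds than this note shows. Statements on the series, on what has been measured and on what is new or still open speak of the compounds shown alone.

In a functional assay on MDA-MB-468 cells (Homo sapiens) for inhibition, read by MTT assay (on this read-out lower numbers stand for stronger inhibition of growth and higher numbers for weaker inhibition of growth), three compounds that share one core have been measured so far. Compound 1 `CC1=C(/C=C/C(C)=C/C=C/C(C)=C\C(=O)Nc2ccc(O)cc2)C(C)(C)CCC1n1ccnc1` gives 6830 nM, compound 2 `CC1=C(/C=C/C(C)=C/C=C/C(C)=C\C(=O)Nc2ccc(F)cc2)C(C)(C)CCC1n1ccnc1` gives 4570 nM, and compound 3 `CC1=C(/C=C/C(C)=C/C=C/C(C)=C\C(=O)NCc2ccccc2)C(C)(C)CCC1n1ccnc1` gives 7240 nM. Compound 3 cannot be told apart from the other two, as shown by a 1.1-fold higher number from compound 1 to compound 3 (0.03 log units; within the scatter) and by a 1.6-fold higher number from compound 2 to compound 3 (0.20 log units; within the scatter).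

The next compound is compound 4 `CC1=C(/C=C/C(C)=C/C=C/C(C)=C\C(=O)Nc2ccccc2O)C(C)(C)CCC1n1ccnc1`, which differs from compound 3 as follows: 2-hydroxyphenyl in place of benzyl on an amide-type nitrogen. In short, 2-hydroxyphenyl takes the place of benzyl on an amide-type nitrogen.

The nearest evidence is compound 1, which carries 4-hydroxyphenyl on that nitrogen, and its step to compound 3 is small. Exchanging hydroxy for fluoro gave a 1.5-fold lower number from compound 1 to compound 2 (0.17 log units; within the scatter), which is also small. Within the data shown here, no measured compound carries 2-hydroxyphenyl, so this exact group remains untested. Among the measured compounds shown here, all the measured steps stay inside the scatter, so no step beyond it is expected here.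

The estimated step is a 1.2-fold lower number from compound 3 to compound 4 (0.08 log units; within the scatter). Compound 4 is expected at about 6000 nM, with an estimated range from 2800 nM to 13000 nM.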

Compound 4, concentration for 50% growth inhibition: 3030 nM
Compound 4: the middle estimate sits 2.0-fold (0.30 log units) above what was measured; low and high end bracket the measured number.
By their numbers in this assay, from the lowest: compounds 4, 2, 1 and 3 (each within the scatter of the next, the first and the last beyond it).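

Moving the hydroxy group, with 2-hydroxyphenyl in place of 4-hydroxyphenyl on the amide-type nitrogen, gives a 2.3-fold lower number from compound 1 to compound 4 (0.35 log units; beyond the scatter) and is one of the first changes at this position to exceed the scatter in this assay. The change from benzyl to 2-hydroxyphenyl also exceeds it, with a 2.4-fold lower number from compound 3 to compound 4 (0.38 log units; beyond the scatter), whereas replacing 4-fluorophenyl with 2-hydroxyphenyl gives only a 1.5-fold lower number from compound 2 to compound 4 (0.18 log units; within the scatter) and so does not separate these two compounds. The results show that the choice of aromatic group on this nitrogen can shift growth inhibition modestly, but nothing available explains why.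

From the compounds shown here alone, it remains open whether the hydroxy group itself is needed, which 2-methoxyphenyl, 2-fluorophenyl or 2-aminophenyl on the same nitrogen could help to show. The effect of 3-hydroxyphenyl at this position is also unknown.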